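Removing the methoxy group from a propargylamine benzyl compound

The source may hold more compounds than are shown below. What is called first, only, known or untested is meant among the compounds shown, and "the series" means these compounds.

Measured so far:
Compound 1 `C#CCN(Cc1ccccc1)C1c2cccc(OC)c2OCC1(C)C` gives 14.7% in an assay on BTI cells for inhibition of Amine oxidase [flavin-containing] B (Homo sapiens), read by fluorescence, with a stated time of 20 min, tested at 1 uM; a lower number here means less inhibition, a higher number more inhibition at the concentration tested (going by the name of the read-out).
Compound 2 `C#CCNC1c2cccc(OC)c2OCC1(C)C` gives 13.8% in this assay.
Compound 3 `C#CCNC1c2cc(C)ccc2OCC1(C)C` gives -6.8% in this assay.

Compound 1 stands highest of the three numbers, though compound 2 sits within the scatter of it: a number 0.9 percentage points lower from compound 1 to compound 2 (within the scatter). Compound 3 lies well below both. Compound 4 `C#CCN(Cc1ccccc1)C1c2ccccc2OCC1(C)C` differs from compound 1 in one place: hydrogen in place of methoxy on an aromatic carbon. Within the data shown here, no measured pair isolates this change. Compounds 2 and 3, which differ in their aromatic substitution and in more than one place, show that the substitution on the aromatic ring can matter, with compound 3 lower. A modest fall is therefore expected, a number 8.7 percentage points lower from compound 1 to compound 4 (within the scatter), with wide uncertainty. Compound 4 is estimated at 6%, between -10% and 22%.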

Compound 4, a percentage reported as inhibition, at one concentration (the size of the read-out at that concentration, not a potency): 2.9%
Estimate against measurement, compound 4: 3.1 percentage points above, and the stated range covers the measured number.
By their numbers in this assay, from the lowest: compounds 3 and 4 (each within the scatter of the next); then compounds 2 and 1 (each within the scatter of the next).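

Among these compounds, with the benzyl group on the amine nitrogen kept in place, removing the methoxy from the aromatic ring lowers the number in this assay by a modest step (a number 11.8 percentage points lower from compound 1 to compound 4 (beyond the scatter)) and gives the first reading of this one change. The methoxy at this position therefore contributes to the inhibition seen with compound 1, although that inhibition is low at the single concentration tested. Nothing available gives a reason for the fall.

Going by these compounds, it remains open whether a fluorine atom, a hydroxyl or an ethoxy group at this position would match the methoxy. The effect of removing the methoxy from compound 2, which has hydrogen in place of benzyl, is also unknown.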